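A few compounds are considered here, and "the series" means these few. Any claim that something is new, unique, unknown or untested is made for them only; others in the source may bear on it.

The study gathers three amides on a shared core, each examined in an ADME assay on BJ cells (Homo sapiens) for cytotoxicity, with a stated time of 72 h; on this read-out lower numbers stand for an effect already at smaller amounts and higher numbers for an effect only at larger amounts of compound. Among the compounds with values here, compound 1 `O=C(Nc1nc(-c2ccc(Cl)cc2)cs1)c1cc([N+](=O)[O-])ccc1Cl` is the one member with a definite number in this assay: in this assay compound 1 gives 18000 nM. Compound 2 `O=C(Nc1ccc(O)c(-c2nc3ccccc3s2)c1)c1cc([N+](=O)[O-])ccc1Cl` reaches only a limit of this assay, and in this assay compound 2 gives > 25000 nM. Compound 3 `O=C(Nc1nc2ccc(F)cc2s1)c1cc([N+](=O)[O-])ccc1Cl` also ends at a limit of this assay, and in this assay compound 3 gives > 27000 nM. Within the data shown here, compound 1 therefore stands as the sole finite reading, while the other two values are limits, as the limit of > 25000 nM in this assay, at which 1 of the 3 values shown sits, and the limit of > 27000 nM in this assay, at which 1 of the 3 values shown sits, record.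

The account now turns from compound 1 to compound 4 `O=C(Nc1nc(-c2ccc(F)c(F)c2)cs1)c1cc([N+](=O)[O-])ccc1Cl`, for which no measurement is at hand. The change is 3,4-difluorophenyl in place of 4-chlorophenyl on an aromatic carbon. Among the measured compounds shown here, no step between two measured compounds exists here to calibrate such an exchange, and the two limits give no direction on their own. A step no larger than the usual scatter is expected, in either direction. Compound 4 is expected to give 20000 nM in this assay, with a range from 9000 nM to 45000 nM. The expected step of a 1.1-fold higher number from compound 1 to compound 4 (0.05 log units; within the scatter) is therefore small, and the result may well come back as a limit rather than a number.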

Compound 4, half-maximal effective concentration: > 27000 nM
Compound 4 gave a limit, no number; the forecaster's own chance of this, stated with the estimate: 40%; middle value at least 1.3-fold (0.13 log units) from the limit.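

Within the data shown here, replacing 4-chlorophenyl with 3,4-difluorophenyl on an aromatic carbon, next to the ring nitrogen of the five-membered aromatic ring, provides the first readable step at this position in this assay, and that step is an at least 1.5-fold higher number from compound 1 to compound 4 (0.17 log units; that floor lies within the scatter). Going by these compounds, only a floor can be given for this step, and that floor lies within the scatter, so the change does not move the read-out toward a lower number, while its true size remains unknown. Compound 4 ends at a limit of this assay, and this is the same limit reached by one other compound shown: the limit of > 27000 nM in this assay, at which 2 of the 4 values shown sit.

The compounds shown leave open whether the definite reading of compound 1 depends on the chlorine itself or would persist with another single substituent on that phenyl ring, such as bromine or methyl. They also leave open whether an amine or a carboxylic acid on that ring, or a longer chain in place of the ring, would bring the read-out back to a definite number.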